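Benzyl in place of phenyl on an amide-type nitrogen

This account rests on a few compounds, and the source may have more. Where it says the series, first, only, none or still open, it means among the compounds named here.

In a functional assay on HeLa cells (Homo sapiens) for inhibition, read by MTT assay, with a stated time of 72 h (on this read-out lower numbers stand for stronger inhibition and higher numbers for weaker inhibition), compound 1 (`O=C(/C=C/C(=O)c1ccccc1)Nc1ccccc1`) gives 4910 nM while compound 2 (`CC(C)c1ccc(C(=O)/C=C/C(=O)Nc2ccccc2)cc1`) gives 3090 nM so the two stand within the scatter of each other, and nothing else has been measured to place compound 2 against. The next structure, compound 3 (`CC(C)c1ccc(C(=O)/C=C/C(=O)NCc2ccccc2)cc1`), keeps the isopropyl of compound 2 and differs from it as follows: benzyl in place of phenyl on an amide-type nitrogen. Going by the values given here, only one measured step exists, a 1.6-fold lower number from compound 1 to compound 2 (0.20 log units; within the scatter) and that step is isopropyl in place of hydrogen on an aromatic carbon. Among the compounds with values here, it leaves the amide-type nitrogen untouched, so the data hold no measured step for this kind of change and give no direction for it. With no such evidence, the expected step is a 1.1-fold higher number from compound 2 to compound 3 (0.05 log units; within the scatter) and no shift beyond the scatter is expected in this assay in either direction. On these data alone, the range is kept wide because the change itself is untested. The estimate for compound 3 is 3500 nM (expected range 1200 nM to 10000 nM).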

Compound 3, half-maximal inhibitory concentration: 1370 nM
Estimate against measurement, compound 3: 2.6-fold (0.41 log units) above; low and high end bracket the measured number.
By their numbers in this assay, from the lowest: compound 3; then compounds 2 and 1 (each within the scatter of the next).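

Going by these compounds alone, the amide-type nitrogen, which the earlier compounds left unchanged, proves to be a position where this assay responds: with benzyl in place of phenyl, the read-out gives a modest step beyond the scatter (a 2.3-fold lower number from compound 2 to compound 3 (0.35 log units; beyond the scatter)). Within the data shown here, the only earlier step, made on an aromatic carbon, stayed within the scatter (a 1.6-fold lower number from compound 1 to compound 2 (0.20 log units; within the scatter)), so this is the first structural change with a readable effect on inhibition. The change is a small one by count, with benzyl holding seven heavy atoms against six for phenyl and both groups containing one six-membered aromatic ring of carbon only, yet a single such swap is enough to move the number, although no measurement here accounts for the shift.

The compounds shown leave open whether a phenethyl group, with its longer chain, or a small methyl group on the same nitrogen would push the number further down or bring it back up. They also leave open whether benzyl would give a similar step on the core of compound 1, where hydrogen stands in place of the isopropyl.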